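The source may hold more compounds than are shown below. What is called first, only, known or untested is meant among the compounds shown, and "the series" means these compounds.

Measured so far:
compound 1, `Cc1ccc(CNc2ncnc3c2ncn3[C@@H]2O[C@H](CO)[C@@H](O)[C@H]2O)cc1` — in a functional assay on HL-60 cells (Homo sapiens) for antiproliferative activity, with a stated time of 72 h (on this read-out lower numbers stand for stronger inhibition and higher numbers for weaker inhibition), compound 1 reaches only a limit, > 166000 nM.
compound 2, `COc1ccccc1CNc1ncnc2c1ncn2[C@@H]1O[C@H](CO)[C@@H](O)[C@H]1O` — compound 2 gives 2300 nM.
compound 3, `COc1ccc(CNc2ncnc3c2ncn3[C@@H]2O[C@H](CO)[C@@H](O)[C@H]2O)c(OC)c1` — compound 3 gives 39000 nM.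

Compound 1 thus stands at the edge of what this assay reports: its entry is a limit, not a number (the limit of > 166000 nM in this assay, at which 1 of the 3 values shown sits). Compound 4, `COc1cccc(CNc2ncnc3c2ncn3[C@@H]2O[C@H](CO)[C@@H](O)[C@H]2O)c1O`, is not yet measured; it differs from compound 1 by 2-hydroxy-3-methoxyphenyl in place of 4-methylphenyl on a saturated chain carbon bound to a nitrogen on an aromatic ring. Two measured steps start from compound 1 and likewise replace the 4-methylphenyl with a methoxy-bearing phenyl: an at least 72-fold lower number from compound 1 to compound 2 (1.85 log units; beyond the scatter) and an at least 4.2-fold lower number from compound 1 to compound 3 (0.62 log units; beyond the scatter). Both point the same way, so a lower number is expected for compound 4 as well, though a 17-fold higher number from compound 2 to compound 3 (1.23 log units; beyond the scatter) shows the size varies with the ring substitution. The expected step is an at least 16-fold lower number from compound 1 to compound 4 (1.22 log units; beyond the scatter). Compound 4 is estimated at 10000 nM, within 2000 nM to 60000 nM.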

Compound 4, half-maximal inhibitory concentration: 150 nM
Estimate against measurement, compound 4: 67-fold (1.82 log units) above; the whole stated range lies above it.
By their numbers in this assay, from the lowest: compound 4; then compound 2; then compound 3. At a limit, above all of these: compound 1.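

At this position, on a saturated chain carbon bound to a nitrogen on an aromatic ring, 2-hydroxy-3-methoxyphenyl outperforms both rings with methoxy groups only, with a 15-fold lower number from compound 2 to compound 4 (1.19 log units; beyond the scatter) and a 260-fold lower number from compound 3 to compound 4 (2.41 log units; beyond the scatter) in this series. It is also the only ring shown with a hydrogen-bond donor, and it gives an at least 1100-fold lower number from compound 1 to compound 4 (3.04 log units; beyond the scatter) as the widest gap so far. That step is open-ended, as one end is a limit: the limit of > 166000 nM in this assay, at which 1 of the 4 values shown sits.

How far the hydroxy alone accounts for the gain stays open. So does how 2-hydroxyphenyl, or an amine in place of the hydroxy, would compare.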